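Pendant aryl swap on the sulfonamide core

The compounds below may be only part of what the source reports. "The series", "measured", "known", "first", "only" and "open" are said of these compounds alone.

Compound 1, `COc1ccc(S(=O)(=O)N2CCc3cccc(-c4ccc(F)nc4)c32)cc1`, gives 135 nM in a functional assay on NCI-H460 cells (Homo sapiens) for inhibition, with a stated time of 72 h (a higher number here means a weaker inhibitor, a lower number a stronger inhibitor), and holds the lowest number of the two measured compounds. For the measured compounds named here, compound 2, `COc1ccc(S(=O)(=O)N2CCc3cccc(-c4cc(OC)c(OC)c(OC)c4)c32)cc1`, gives 6340 nM in this assay, a number far beyond the scatter away from compound 1; with only these two values in hand there is no step between them to quote, so the comparison rests on the bare numbers alone, and they say that the pendant aromatic group at the shared core decides much of the potency here.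

Compound 3, `COc1ccc(S(=O)(=O)N2CCc3cccc(-c4ccc(N)cc4)c32)cc1`, has not yet been measured. It differs from compound 1 only at one site: 4-aminophenyl in place of 6-fluoropyridin-3-yl on an aromatic carbon. Nothing measured in the set covers this exact exchange, so the size of the step is open. Given that the one other pendant ring of the series, in compound 2 with 6340 nM, lies well above compound 1, a loss of some size is expected, though the 4-aminophenyl group is closer in bulk to the 6-fluoropyridin-3-yl group than the ring of compound 2 is.

Compound 3 is therefore estimated at 400 nM, with a range of 80 nM to 2500 nM. The expected step of a 3.0-fold higher number from compound 1 to compound 3 (0.47 log units; beyond the scatter) is a moderate weakening, likely beyond the scatter but far short of the gap to compound 2.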

Compound 3, half-maximal inhibitory concentration: 288 nM
The estimate for compound 3 lay 1.4-fold (0.14 log units) above the measured number; low and high end bracket the measured number.
By their numbers in this assay, from the lowest: compound 1; then compound 3; then compound 2.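

The exchange of 6-fluoropyridin-3-yl for 4-aminophenyl shows that this aromatic carbon of the shared core accepts a pendant ring of carbon only, with one more hydrogen-bond donor, at a modest cost in this assay: a 2.1-fold higher number from compound 1 to compound 3 (0.33 log units; beyond the scatter). Neither the ring nitrogen nor the fluorine of compound 1 is therefore needed to keep the number in the range of compound 1, and compound 3 at 288 nM remains far closer to that range than compound 2 at 6340 nM does, so the pendant rings of equal size tested here stay near each other while the trimethoxyphenyl ring stands well apart. No measurement in hand bears on what lies behind the step.

On these data alone, the change removes the ring nitrogen and the fluorine and adds the amine all at once, so the share of each in the step stays open, and a 4-fluorophenyl or unsubstituted phenyl group on the same carbon would begin to separate them. As far as these compounds go, whether the hydrogens of the amine matter is equally open, a question that a 4-dimethylaminophenyl or 4-acetamidophenyl group would address.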